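Swapping the Amino Group for Methoxy on the Ketone Ring

The source may report more compounds than this note shows. Statements on the series, on what has been measured and on what is new or still open speak of the compounds shown alone.

Measured compounds:
Compound 1, `COc1cc(-c2cc(/C=C/C(=O)c3ccc(N)cc3)[nH]n2)cc(OC)c1OC`: 3240 nM
Compound 2, `COc1ccc(-c2cc(/C=C/C(=O)c3ccc(N)cc3)[nH]n2)cc1OC`: 5120 nM
Compound 3, `COc1ccc(-c2cc(/C=C/C(=O)c3cc(OC)c(OC)c(OC)c3)[nH]n2)cc1OC`: 3160 nM

All three were tested in a functional assay on RXF 393 cells (Homo sapiens) for inhibition, read by sulforhodamine B assay, with a stated time of 48 h; on this read-out higher numbers stand for weaker inhibition of growth and lower numbers for stronger inhibition of growth. Compound 1 stands second highest of the three numbers, yet its distance to both neighbours is small: compound 3 sits almost on the same value, and compound 2 differs by a 1.6-fold higher number from compound 1 to compound 2 (0.20 log units; within the scatter), a step that comes from a hydrogen in place of methoxy on an aromatic carbon and lies within the scatter. In short, the three measured compounds cannot be told apart on this read-out.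

Compound 4, `COc1ccc(C(=O)/C=C/c2cc(-c3cc(OC)c(OC)c(OC)c3)n[nH]2)cc1`, is built from compound 1 by the change (methoxy in place of amino on an aromatic carbon), on an aromatic carbon of a six-membered aromatic ring of carbon only, para to a large group. Going by the values given here, no measured step alters this ring in the same way; the single measured step concerns the other aromatic ring and stays within the scatter. Compound 3, which carries a different substitution on the ketone-bearing ring, also lands beside compound 1. The expected step of a 1.1-fold higher number from compound 1 to compound 4 (0.03 log units; within the scatter) is therefore none beyond the scatter. Compound 4 is estimated at 3500 nM, with a likely range from 1500 nM to 8500 nM.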

Compound 4, concentration for total growth inhibition: 2560 nM
Estimate against measurement, compound 4: 1.4-fold (0.14 log units) above; the measured number falls inside the stated range.
By their numbers in this assay, from the lowest: compounds 4, 3, 1 and 2 (each within the scatter of the next).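

Going by these compounds alone, replacing the amino group with methoxy on the aromatic carbon para to a large group gives, in this assay, a 1.3-fold lower number from compound 1 to compound 4 (0.10 log units; within the scatter), and this is the first measured change at this place. The amino group and its hydrogen-bond donor can therefore be exchanged here for methoxy, which has no such donor and one more heavy atom, without a difference this read-out can resolve, at least on the core of compound 1. Nothing measured here speaks to why the number holds steady under this swap.

This single pair cannot show whether the place tolerates change in general, since a hydroxyl group, a chlorine atom or a carboxylic acid on the same carbon might still move the number beyond the scatter. Going by these compounds, it also remains open whether the same swap would behave alike on the core of compound 2, which lacks one methoxy group on the other aromatic ring, so the flat result cannot yet be extended beyond compound 1 and compound 4.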